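Swapping iodine for a fluorophenyl alkyne on the shared core

The compounds below may be only part of what the source reports. "The series", "measured", "known", "first", "only" and "open" are said of these compounds alone.

Of the compounds shown here, three have been measured in an assay on CHO cells for displacement of a labelled ligand from adenosine receptor A3 (Homo sapiens); a higher number here means a weaker inhibitor, a lower number a stronger inhibitor. Compound 1, `CCC(=O)[C@H]1O[C@@H](n2cnc3c(N)nc(C#Cc4ccccc4)nc32)[C@H](O)[C@@H]1O`, carries a phenylethynyl group on its core and a propanoyl group on its sugar; in this assay compound 1 gives 7.3 nM. Compound 2, `CONc1nc(C#CCCCC#N)nc2c1ncn2[C@@H]1O[C@H](CO)[C@@H](O)[C@H]1O`, carries a methoxyamino group and a nitrile-ended alkyne chain, and compound 2 gives 4.1 nM. Compound 3, `CCNC(=O)[C@H]1O[C@@H](n2cnc3c(NOC)nc(I)nc32)[C@H](O)[C@@H]1O`, has the methoxyamino group, an iodo group on the core and an ethylamide on the sugar; compound 3 gives 2.8 nM, the lowest of the three numbers, within the scatter of compound 2 and beyond the scatter from compound 1.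

Compound 4, `CCNC(=O)[C@H]1O[C@@H](n2cnc3c(NOC)nc(C#Cc4ccc(F)cc4)nc32)[C@H](O)[C@@H]1O`, keeps everything of compound 3 except one group: 2-(4-fluorophenyl)ethynyl in place of iodo on an aromatic carbon. Within the data shown here, no measured pair isolates this exact exchange, so the expected size of the step rests on what the three values show. A phenylethynyl group is already present in compound 1 at 7.3 nM, and compound 2 with an alkyne in the same position gives 4.1 nM, both only modestly above compound 3.

The expected outcome is therefore a small rise that stays within the scatter, estimated as a 1.8-fold higher number from compound 3 to compound 4 (0.25 log units; within the scatter). Compound 4 is estimated at 5 nM, with a range from 1.5 nM to 18 nM.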

Compound 4, inhibition constant: 3.2 nM
The estimate for compound 4 lay 1.6-fold (0.19 log units) above the measured number; measured number inside the range.
By their numbers in this assay, from the lowest: compounds 3, 4, 2 and 1 (each within the scatter of the next, the first and the last beyond it).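

In this assay, putting 2-(4-fluorophenyl)ethynyl in place of iodo on the aromatic carbon between two ring nitrogen atoms gives a 1.1-fold higher number from compound 3 to compound 4 (0.06 log units; within the scatter), the first step shown between compounds that differ in one place. At this position, with the methoxyamino group and the ethylamide held fixed, a lone iodine and a group of 9 heavy atoms with an aromatic ring and a triple bond therefore cannot be told apart in this measurement. No measurement at hand accounts for the number holding steady across so large an exchange.

On these data alone, it remains open whether the fluorine on the ring has any bearing on the number, a question that a plain phenylethynyl on this same core would address. As far as these compounds go, it is also open whether this tolerance extends to quite different groups on the same carbon, such as an amine or a carboxylic acid, which would show how far the position can be varied before the number moves beyond the usual scatter.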